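Swapping Methylsulfanyl for a Selenium Group on a Shared Core

The source may report more compounds than this note shows. Statements on the series, on what has been measured and on what is new or still open speak of the compounds shown alone.

compound 1 `CS/C(=N\C(=O)c1sccc1Cl)NC(=O)c1sccc1Cl`: > 100000 nM
compound 2 `CS/C(=N\C(=O)c1ccno1)NC(=O)c1ccno1`: > 100000 nM

In a functional assay on HT-29 cells (Homo sapiens) for cytotoxicity, read by MTT assay, with a stated time of 72 h (a higher number here means that more compound is tolerated, a lower number that less compound is tolerated), compound 1 gives > 100000 nM, which is a limit of the assay rather than a number. Compound 2 likewise gives > 100000 nM, also a limit. Compound 1 therefore stands at the limit of > 100000 nM in this assay, at which 2 of the 2 values shown sit. Compound 3 `C[Se]/C(=N\C(=O)c1sccc1Cl)NC(=O)c1sccc1Cl` differs from compound 1 by a group of 2 heavy atoms (1 carbon, 1 selenium; no ring) in place of a group of 2 heavy atoms (1 carbon, 1 sulfur; no ring), on a carbon with a double bond to nitrogen. For the measured compounds named here, no measured pair shows the effect of this change, so a number no higher from compound 1 to compound 3 (the limit leaves the size open) is expected to be no step beyond the scatter. Compound 3 is accordingly estimated at 100000 nM, within 30000 nM to 300000 nM, and most probably reported again only as a limit.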

Compound 3, concentration lethal to 50% of the cells: > 100000 nM
Compound 3: only a limit was reported; the forecaster's own chance of this, stated with the estimate: 80%; the middle value sits exactly at the limit.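

Compound 1 and compound 3 both give only a limit rather than a number, so no step can be read between them: the limit of > 100000 nM in this assay, at which 3 of the 3 values shown sit.

The compounds shown leave open whether replacing methylsulfanyl with the selenium group changes cytotoxicity at all.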